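The source may report more compounds than this note shows. Statements on the series, on what has been measured and on what is new or still open speak of the compounds shown alone.

In a physicochemical assay for solubility, read by spectrophotometry, in phosphate buffer, with a stated time of 2 h, at pH 7.4 (a lower number here means a less soluble compound, a higher number a more soluble compound), three members of the series have been measured so far. Compound 1 `COc1ccc2[nH]c(C(=O)N3CC(=O)N(Cc4cc5ccccc5[nH]4)[C@@H](Cc4ccccc4)C3)cc2c1` gives 11000 nM. Compound 2 `COc1ccc2[nH]c(C(=O)N3CC(=O)N(Cc4ccccc4)[C@@H](COC(C)(C)C)C3)cc2c1` gives 65500 nM. Compound 3 `COc1ccc2[nH]c(C(=O)N3CC(=O)N(Cc4ccccc4)[C@@H](CN4CCN(c5ccc(F)cc5)CC4)C3)cc2c1` gives 20700 nM. Compound 2 stands highest of the three numbers; the nearest to it is compound 3 and the furthest is compound 1, and both of those gaps lie beyond the usual scatter, so compound 2 is the most soluble of the three in this assay.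

Compound 4 `COc1ccc2[nH]c(C(=O)N3CC(=O)N(Cc4ccccc4)[C@@H](CN4CCC5(CCCC5)CC4)C3)cc2c1` has not yet been measured in this assay. Relative to compound 2 the change is a group of 10 heavy atoms (9 carbon, 1 nitrogen; one five-membered non-aromatic ring of carbon only, one six-membered non-aromatic ring with 1 hetero atom) in place of a group of 5 heavy atoms (4 carbon, 1 oxygen; no ring), on a saturated chain carbon bound to a saturated ring carbon. Among the compounds with values here, no step between two measured compounds that differ in one place is available, so the size of the step cannot be read from a matched pair. Within the data shown here, what the measured numbers show is that the one other compound carrying a nitrogen-linked ring on the same chain position sits lower than compound 2: compound 3 gives 20700 nM. On that basis a downward step is expected for compound 4, a 2.6-fold lower number from compound 2 to compound 4 (0.42 log units; beyond the scatter), beyond the scatter but not large. Compound 4 is estimated to give 25000 nM in this assay, within a range of 8000 nM to 70000 nM.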

Compound 4, solubility: 5000 nM
Estimate against measurement, compound 4: 5.0-fold (0.70 log units) above; measured number outside the range, below it.
By their numbers in this assay, from the lowest: compound 4; then compounds 1 and 3 (each within the scatter of the next); then compound 2.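

In this assay, the saturated chain carbon bound to a saturated ring carbon now has its first reading from a pair differing in one place: a 13-fold lower number from compound 2 to compound 4 (1.12 log units; beyond the scatter), a large step on replacing tert-butoxy with the group of two non-aromatic rings. Within the data shown here, the place also responds to what lies beyond the linking nitrogen, which the earlier compounds could not show: compound 3 gives 20700 nM and compound 4 gives 5000 nM, so a nitrogen-linked ring on this chain does not fix the number by itself, and compound 4 now holds the lowest of the four numbers. Nothing available accounts for the size of the step or for the gap between these two compounds.

The compounds shown do not separate the contribution of the ring nitrogen from that of the carbon-only five-membered ring or of the overall group size, and a morpholine or a dimethylamino group at this same place would help to tell these apart. On these data alone, it also remains open whether a carboxylic acid on this chain would keep the number near that of compound 2 or move it towards that of compound 4.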